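Ring-nitrogen substituent change: compound 2 to compound 4

The source may report more compounds than this note shows. Statements on the series, on what has been measured and on what is new or still open speak of the compounds shown alone.

Measured so far:
compound 1 `NC(=O)c1c(NC(=O)c2ccccc2Cl)sc2c1CCN(Cc1ccccc1F)C2`: 21800 nM
compound 2 `NC(=O)c1c(NC(=O)c2ccccc2Cl)sc2c1CCN(Cc1cc(Cl)cc(Cl)c1)C2`: 15800 nM
compound 3 `NC(=O)c1c(NC(=O)c2ccccc2F)sc2c1CCN(Cc1ccc(Cl)cc1Cl)C2`: 13100 nM

All three values come from a functional assay on HL-60 cells (Homo sapiens) for antiproliferative activity, with a stated time of 24 h; a higher number here means a weaker inhibitor, a lower number a stronger inhibitor. They lie within the usual scatter of one another, so no order among compounds 1, 2 and 3 can be claimed; compound 2 sits among them, and its step from compound 1 is a 1.4-fold lower number from compound 1 to compound 2 (0.14 log units; within the scatter).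

Compound 4 `Cc1ccccc1NC(=S)N1CCc2c(sc(NC(=O)c3ccccc3Cl)c2C(N)=O)C1` differs from compound 2 by a group of 10 heavy atoms (8 carbon, 1 nitrogen, 1 sulfur; one six-membered aromatic ring of carbon only) in place of a group of 9 heavy atoms (7 carbon, 2 chlorine; one six-membered aromatic ring of carbon only), on an amine nitrogen in a ring. Among the measured compounds shown here, the only measured step at the same place, a 1.4-fold lower number from compound 1 to compound 2 (0.14 log units; within the scatter), swapped one aromatic ring for another on the same saturated chain carbon and stayed within the scatter. For the measured compounds named here, the present change goes further, exchanging the whole group bound to the ring nitrogen, and no measured pair covers that kind of exchange. With only a within-scatter precedent, no step beyond the scatter is expected in this assay, in either direction, though the uncertainty is wider than for the measured steps.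

Compound 4 is therefore estimated at 16000 nM, with a range of 5000 nM to 50000 nM; this estimate means a step of a 1.0-fold higher number from compound 2 to compound 4 (0.01 log units; within the scatter).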

Compound 4, half-maximal inhibitory concentration: 22600 nM
Beside the measured number, compound 4's estimate is 1.4-fold (0.15 log units) below it; measured number inside the range.
By their numbers in this assay, from the lowest: compounds 3, 2, 1 and 4 (each within the scatter of the next).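

In this assay the exchange of the whole group on the amine nitrogen in a ring now has measured steps (a 1.4-fold higher number from compound 2 to compound 4 (0.16 log units; within the scatter)) and (a 1.0-fold higher number from compound 1 to compound 4 (0.02 log units; within the scatter)). The earlier step only swapped one aromatic ring for another on the same saturated chain carbon, whereas the entering group of 10 heavy atoms brings 1 hydrogen-bond donor, 1 hydrogen-bond acceptor and 1 double bond outside aromatic rings, and neither step leaves the scatter. No measurement is available that bears on why these compounds fall so close together.

The compounds shown do not separate the contribution of the sulfur, the nitrogen or the aromatic ring within the entering group. Also open, from the compounds shown here alone, is whether a group without an aromatic ring on this nitrogen, such as a short chain ending in a carboxylic acid or an amine, would give a step beyond the scatter.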